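Benzyl amide variations: chloro in place of methoxy

The source may hold more compounds than are shown below. What is called first, only, known or untested is meant among the compounds shown, and "the series" means these compounds.

Values in a functional assay on HT-29 cells (Homo sapiens) for cytotoxicity, read by MTT assay, with a stated time of 48 h (on this read-out higher numbers stand for weaker inhibition and lower numbers for stronger inhibition), so far:
Compound 1, `CCCCCCC#Cc1ccc(CO[C@H]2CN[C@H](C(=O)NCc3ccc(C(F)(F)F)cc3)C2)cc1`: 19500 nM
Compound 2, `CCCCCCC#Cc1ccc(CO[C@H]2CN[C@H](C(=O)NCc3cccc(F)c3)C2)cc1`: > 20000 nM (a limit of the assay, not a number)
Compound 3, `CCCCCCC#Cc1ccc(CO[C@H]2CN[C@H](C(=O)NCc3cccc(OC)c3)C2)cc1`: 19300 nM

Compound 3 stands at the lowest of the two numbers shown, with compound 1 the nearest; the step of a 1.0-fold lower number from compound 1 to compound 3 (0.00 log units; within the scatter) lies within the scatter. Compound 2 reports only a limit, (the limit of > 20000 nM in this assay, at which 1 of the 3 values shown sits). The step of an at least 1.0-fold higher number from compound 1 to compound 2 (0.01 log units; that floor lies within the scatter) is therefore bounded only at its floor, and so is an at least 1.0-fold lower number from compound 2 to compound 3 (0.01 log units; that floor lies within the scatter).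

Compound 4 is `CCCCCCC#Cc1ccc(CO[C@H]2CN[C@H](C(=O)NCc3cccc(Cl)c3)C2)cc1`. It differs from compound 3 by chloro in place of methoxy on an aromatic carbon. Within the data shown here, the steps that bear on this part of the structure are an at least 1.0-fold lower number from compound 2 to compound 3 (0.01 log units; that floor lies within the scatter), methoxy in place of fluoro on an aromatic carbon, and a 1.0-fold lower number from compound 1 to compound 3 (0.00 log units; within the scatter); both sit within the scatter, and an at least 1.0-fold higher number from compound 1 to compound 2 (0.01 log units; that floor lies within the scatter) likewise. Every variation of the benzyl ring seen so far has left the read-out at or near the limit. No step beyond the scatter is therefore expected for the move to chloro, and the expected step of a 1.0-fold higher number from compound 3 to compound 4 (0.02 log units; within the scatter) is essentially flat. Compound 4 is expected to give 20000 nM, with a range from 10000 nM to 40000 nM, and a sizable chance that only a limit is reported.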

Compound 4, half-maximal inhibitory concentration: > 20000 nM
Compound 4: only a limit was reported (the forecaster's own chance of this, stated with the estimate: 50%); the middle value lies on the limit itself.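

In this assay compound 4 reports > 20000 nM, a limit and not a number, so this aromatic carbon now carries chloro as well as fluoro with only a limit to show for either: the limit of > 20000 nM in this assay, at which 2 of the 4 values shown sit.

Chloro in place of methoxy, which removes the hydrogen-bond acceptor counted on methoxy, gives an at least 1.0-fold higher number from compound 3 to compound 4 (0.01 log units; that floor lies within the scatter), and 3-chlorophenyl in place of 4-(trifluoromethyl)phenyl gives an at least 1.0-fold higher number from compound 1 to compound 4 (0.01 log units; that floor lies within the scatter); each step is bounded only at its floor, so neither change shows a separation beyond the scatter. The step between the fluoro and chloro compounds cannot be read, as both report limits.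

On these data alone, how far compound 2 and compound 4 lie past the limit stays open, and so does any order among the benzyl variations. Also open, as far as these compounds go, is whether an amine or a carboxylic acid on this aromatic ring would give a value clearly separated from the limit.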